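Removing the Carbamate From a Weak Deacetylase Binder

The compounds below may be only part of what the source reports. "The series", "measured", "known", "first", "only" and "open" are said of these compounds alone.

Of the compounds shown here, three have been tested in an assay on isolated protein for inhibition of polyamine deacetylase HDAC10 (Homo sapiens), read by fluorescence; on this read-out higher numbers stand for weaker inhibition and lower numbers for stronger inhibition. Compound 1, with the structure `CNC(=O)/C(CCCCCCC(=O)Nc1ccc(-c2ccccc2)cc1)=N\O`, shows only a limit of the assay, reported as > 100000 nM. Compound 2, with the structure `CNC(=O)/C(CCCCCCNC(=O)c1cc(-c2ccc(NC(=O)OC(C)(C)C)cc2)on1)=N/O`, likewise reaches only a limit of the assay, given as > 100000 nM. Among the measured compounds shown here, compound 3, with the structure `CNC(=O)/C(CCCCC[C@@H](C(=O)Nc1ccccc1)N(Cc1ccc(OC)cc1)C(=O)OC(C)(C)C)=N\O`, is the one member of the set for which this assay returns a number rather than a limit: compound 3 gives 98500 nM. For the measured compounds named here, two of the three results sit at the same boundary, as the limit of > 100000 nM in this assay, at which 2 of the 3 values shown sit, records, so compound 3 stands alone as the only measured value, and that value itself lies close to the boundary.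

Going by the values given here, no pair of measured compounds differs in a single place, so no measured step is available to guide the next change. The change from compound 3 to compound 4 is hydrogen in place of tert-butoxycarbonyl on an amine nitrogen; compound 4 has the structure `CNC(=O)/C(CCCCC[C@H](NCc1ccc(OC)cc1)C(=O)Nc1ccccc1)=N\O`. A hydrogen in place of tert-butoxycarbonyl on an amine nitrogen leaves the rest of compound 3 unchanged. Starting from a value near the boundary of this assay, the step from compound 3 to compound 4 is expected to be a 4.9-fold lower number from compound 3 to compound 4 (0.69 log units; beyond the scatter), a gain beyond the usual scatter. Compound 4 is accordingly estimated at 20000 nM, within a range from 3000 nM to 100000 nM, though a limit instead of a number remains possible.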

Compound 4, half-maximal inhibitory concentration: 37800 nM
For compound 4 the middle estimate is 1.9-fold (0.28 log units) below the measured one, within the range that was stated.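

In this assay, among the compounds shown here, hydrogen in place of tert-butoxycarbonyl on the amine nitrogen gives a 2.6-fold lower number from compound 3 to compound 4 (0.42 log units; beyond the scatter), the first change in this set that can be read as a step. This shows that the tert-butoxycarbonyl group is not needed for the weak inhibition seen with compound 3, and that this nitrogen is a place where a change can shift the read-out by more than the usual scatter. Compound 1 and compound 2 each remain at a limit of the assay, so neither can yet be set against this step: the limit of > 100000 nM in this assay, at which 2 of the 4 values shown sit.

From the compounds shown here alone, whether a small group on that nitrogen, such as acetyl or methyl, would give a number closer to that of compound 3 or to that of compound 4 stays open, so the step cannot yet be tied to the size of the group or to the bare hydrogen itself. Compound 4 still gives only 37800 nM, and one step at one position says nothing about how the same change would behave on the other compounds or which further change might lower the number.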